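This account rests on a few compounds, and the source may have more. Where it says the series, first, only, none or still open, it means among the compounds named here.

Working notes on the series. Three measured members share one core. Compound 1 `c1cncc(CN(CCCCN(C[C@H]2Cc3ccccc3CN2)[C@H]2CCCc3cccnc32)Cc2cccnc2)c1` was run in a functional assay on cells for agonist activity at C-X-C chemokine receptor type 4 (Homo sapiens), read by fluorescence and calcium flux, with a stated time of 90 s; a lower number here means that less compound is needed, a higher number that more compound is needed for the effect; compound 1 gives > 30000 nM, which is a limit of the assay and not a number. Compound 2 `c1ccc2c(c1)CN[C@@H](CN(CCCCNCC1CCCCC1)[C@H]1CCCc3cccnc31)C2` in this assay gives > 30000 nM, again a limit rather than a number. Compound 3 `c1ccc2c(c1)CN[C@@H](CN(Cc1ccc(CNCc3ccncc3)cc1)[C@H]1CCCc3cccnc31)C2` in this assay gives > 30000 nM, also a limit. Where compound 2 stands is therefore only a limit, and the two further values shown are limits as well; the limit of > 30000 nM in this assay, at which 3 of the 3 values shown sit, records this. Among the measured compounds shown here, no step between two measured compounds is available, so nothing measured can yet be set against the scatter, and no direction is known.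

Compound 4 `CC(C)(CCN(C[C@H]1Cc2ccccc2CN1)[C@H]1CCCc2cccnc21)CNC1CCOCC1` has not yet been measured in this assay. It differs from compound 2 in one place: a group of 11 heavy atoms (9 carbon, 1 nitrogen, 1 oxygen; one six-membered non-aromatic ring with 1 hetero atom) in place of a group of 10 heavy atoms (9 carbon, 1 nitrogen; one six-membered non-aromatic ring of carbon only), on a saturated chain carbon, two bonds along the chain from an amine nitrogen. With every measured value at the limit, the three results give no direction for this change. The expected step is a number no higher from compound 2 to compound 4 (the limit leaves the size open), none beyond the scatter. For compound 4 the expected value in this assay is estimated at 30000 nM, within a range from 10000 nM to 100000 nM, and a limit rather than a number is the more likely report.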

Compound 4, half-maximal effective concentration: > 30000 nM
Compound 4 gave a limit, no number; the forecaster's own chance of this, stated with the estimate: 80%; the middle value lies on the limit itself.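

Compound 4 gives > 30000 nM in this assay, which is a limit and not a number. Among the compounds shown here, compound 2 is also only a limit, so no step from compound 2 to compound 4 can be read. The compounds shown leave open whether any change on the shared core gives a measurable value, and in which direction the series moves: the limit of > 30000 nM in this assay, at which 4 of the 4 values shown sit.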